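The source may report more compounds than this note shows. Statements on the series, on what has been measured and on what is new or still open speak of the compounds shown alone.

Compound 3 `Cc1cc(C)cc(-n2cc(COc3ccc4c(C)cc(=O)oc4c3)nn2)c1` belongs to a small set of analogues that share one core and differ only in the aryl group on an aromatic nitrogen. In an ADME assay on Huh-7 cells (Homo sapiens) for cytotoxicity, read by MTT assay, with a stated time of 72 h (a higher number here means that more compound is tolerated, a lower number that less compound is tolerated), compound 3 gives > 100 ug/mL, which is a limit of the assay rather than a number. Compound 1 `Cc1cc(=O)oc2cc(OCc3cn(-c4ccc(F)c(Cl)c4)nn3)ccc12` gives > 100 ug/mL in this assay, likewise a limit. Compound 2 `Cc1cc(=O)oc2cc(OCc3cn(-c4ccccc4F)nn3)ccc12` gives > 100 ug/mL in this assay, again a limit. Accordingly a step that the two limits leave unreadable from compound 1 to compound 2, a step that the two limits leave unreadable from compound 1 to compound 3 and a step that the two limits leave unreadable from compound 2 to compound 3, because of the limit of > 100 ug/mL in this assay, at which 3 of the 3 values shown sit. Compound 4 `Cc1cc(F)ccc1-n1cc(COc2ccc3c(C)cc(=O)oc3c2)nn1` differs from compound 3 by 4-fluoro-2-methylphenyl in place of 3,5-dimethylphenyl on an aromatic nitrogen. Going by the values given here, no measured step can size this change, and nothing in the set points away from the limit. Compound 4 is therefore expected to show 150 ug/mL (60 ug/mL to 400 ug/mL) in this assay. The expected step is a step that the limit leaves unreadable from compound 3 to compound 4, most likely again reported only as a limit.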

Compound 4, half-maximal cytotoxic concentration: > 100 ug/mL
Compound 4 was reported as a limit; the forecaster's own chance of this, stated with the estimate: 85%; the middle value lies beyond the limit too.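

Compound 4 sits at the same limit as compounds 1, 2 and 3 in this assay, so no step between compound 4 and any of them can be read: the limit of > 100 ug/mL in this assay, at which 4 of the 4 values shown sit.

The compounds shown leave open how far past that limit each one lies, and whether the aryl group matters at all.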